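Amide substituent change on the shared core in the proliferation assay

The source may hold more compounds than are shown below. What is called first, only, known or untested is meant among the compounds shown, and "the series" means these compounds.

Compound 2, `CCn1c(C(=O)N(CCC#N)CCC#N)ccc1C(CC)(CC)c1ccc(OCCC(O)(CC)CC)c(C)c1`, is one of two amides built on the shared core. In a functional assay on MCF7 cells (Homo sapiens) for antiproliferative activity, read by MTT assay, with a stated time of 48 h (a lower number here means a stronger inhibitor, a higher number a weaker inhibitor), compound 2 gives only a limit, > 50000 nM. Compound 1, `CCn1c(C(=O)NCC#N)ccc1C(CC)(CC)c1ccc(OCCC(O)(CC)CC)c(C)c1`, likewise gives only a limit in this assay, > 50000 nM. For the measured compounds named here, the single measured step, a step that the two limits leave unreadable from compound 1 to compound 2, is therefore not readable, and the only evidence on it is the limit of > 50000 nM in this assay, at which 2 of the 2 values shown sit. Compound 3, `CCOC(=O)C(CC(=O)OC)NC(=O)c1ccc(C(CC)(CC)c2ccc(OCCC(O)(CC)CC)c(C)c2)n1CC`, is not yet measured; it differs from compound 2 by a group of 12 heavy atoms (7 carbon, 1 nitrogen, 4 oxygen; no ring) in place of a group of 9 heavy atoms (6 carbon, 3 nitrogen; no ring), on a carbonyl carbon. Going by the values given here, no measured step bears on this change in a readable way, since both values so far sit at the same limit. For compound 3 no step beyond the scatter can be foreseen, and the estimated step is a step that the limit leaves unreadable from compound 2 to compound 3. Compound 3 is expected to give about 60000 nM in this assay, with a range from 15000 nM to 250000 nM, most likely again as a limit.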

Compound 3, half-maximal inhibitory concentration: 390 nM
Estimate against measurement, compound 3: 150-fold (2.19 log units) above; measured number outside the range, below it.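

Working notes: the substituent at this position is not silent. For the compounds shown here, on the carbonyl carbon, the group of 12 heavy atoms gives in this assay an at least 120-fold lower number from compound 2 to compound 3 (2.10 log units; beyond the scatter), the first readable step. Compared on the amide-type nitrogen, the group of 11 heavy atoms gives an at least 120-fold lower number from compound 1 to compound 3 (2.10 log units; beyond the scatter), and both steps start from limits rather than numbers, so each gives only a minimum size: the limit of > 50000 nM in this assay, at which 2 of the 3 values shown sit.

The compounds shown do not separate the parts of the group of 12 heavy atoms, which differs from both nitrile-bearing groups in several features at once, so the part that carries the step stays unknown. Also open, as far as these compounds go, is what a carboxylic acid in place of either ester, or a longer chain between the amide nitrogen and an ester, would give.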